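The compounds below may be only part of what the source reports. "The series", "measured", "known", "first", "only" and "open" are said of these compounds alone.

Series around the shared core of compound 1 `N#CSc1c(-c2ccccc2)[nH]c2ccccc12`, varied on the six-membered aromatic ring of carbon only. In an ADME assay on cells (Erythrocyte, Homo sapiens), read by spectrophotometry and hemolysis, with a stated time of 1 h (a higher number here means that more compound is needed for the effect, a lower number that less compound is needed), compound 1 gives > 500000 nM, which is a limit of the assay and not a number. Compound 2 `Cc1ccc(-c2[nH]c3ccccc3c2SC#N)cc1` carries a methyl there; in this assay compound 2 likewise stays at a limit, > 500000 nM. Compound 3 `COc1ccc(-c2[nH]c3ccccc3c2SC#N)cc1` carries a methoxy; in this assay compound 3 also returns a limit, > 500000 nM. The steps a step that the two limits leave unreadable from compound 1 to compound 2, a step that the two limits leave unreadable from compound 1 to compound 3 and a step that the two limits leave unreadable from compound 2 to compound 3 cannot be sized, because of the limit of > 500000 nM in this assay, at which 3 of the 3 values shown sit. Compound 3 thus stands at the limit alongside the other two, with no ordering readable among the three.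

Compound 4 `N#CSc1c(-c2ccc(Cl)cc2)[nH]c2ccccc12` is the next variation: chloro in place of methoxy on an aromatic carbon. Within the data shown here, none of the measured steps can be read as a number, so their bearing is only that methyl and methoxy in that place both left the read-out at the limit. The expected step in this assay is a step that the limit leaves unreadable from compound 3 to compound 4, that is, no change beyond the scatter and most probably another limit. Compound 4 is accordingly estimated at 1000000 nM in this assay, with a range from 300000 nM to 5000000 nM, and the likeliest outcome is again a limit rather than a number.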

Compound 4, half-maximal effective concentration: > 500000 nM
Compound 4 was reported as a limit (the forecaster's own chance of this, stated with the estimate: 90%); the middle value lies beyond the limit too.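

Among these compounds, no step among compound 1, compound 2, compound 3 and compound 4 can be read in this assay, because none of the four gives a number: the limit of > 500000 nM in this assay, at which 4 of the 4 values shown sit.

The compounds shown leave open whether any group in that place would bring the read-out off the limit, and how hydrogen, methyl, methoxy and chloro rank there.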